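Swapping Ethyl for Fluoro on a Pyrimidine Ring

The source may report more compounds than this note shows. Statements on the series, on what has been measured and on what is new or still open speak of the compounds shown alone.

Going by the values given here, compound 2 `CCc1cnc(N2CCC(c3coc4c(N5CCc6cc(S(C)(=O)=O)ccc65)ncnc34)CC2)nc1` holds the higher of the two numbers measured so far: in a functional assay on cells for agonist activity at Glucose-dependent insulinotropic receptor (Homo sapiens), read by a luciferase reporter, with a stated time of 4 h (on this read-out lower numbers stand for smaller maximal responses and higher numbers for larger maximal responses), compound 2 gives 154%, while compound 1 `CC(C)(C)OC(=O)N1CCC(c2coc3c(N4CCCc5cc(S(C)(=O)=O)ccc54)ncnc23)CC1` gives 1% in this assay, a gap beyond the scatter. Compound 3 `CS(=O)(=O)c1ccc2c(c1)CCN2c1ncnc2c(C3CCN(c4ncc(F)cn4)CC3)coc12` has not yet been measured. It differs from compound 2 in one place: fluoro in place of ethyl on an aromatic carbon. Among the compounds with values here, no measured pair shows this change, so its effect is unknown. The step is estimated as a number 29 percentage points lower from compound 2 to compound 3 (beyond the scatter), a modest downward move that may still fall within the scatter. Compound 3 is expected to give 125% in this assay, with a range from 70% to 165%.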

Compound 3, largest response reached (Emax), in percent of the reference or control that the assay uses: 229%
For compound 3 the middle estimate is 104 percentage points below the measured one; the whole stated range lies below it.
By their numbers in this assay, from the lowest: compound 1; then compound 2; then compound 3.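

In this assay, fluoro in place of ethyl on the pyrimidine ring gives a number 75 percentage points higher from compound 2 to compound 3 (beyond the scatter), so the group on this one carbon alone can strongly change the maximal response. Here the group with one heavy atom gives a larger response than the group with two. No measurement shown bears on the reason for this rise. From the compounds shown here alone, whether the number of heavy atoms or fluoro itself matters remains open. Chloro or methoxy on the same carbon would help to separate the two.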